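This account rests on a few compounds, and the source may have more. Where it says the series, first, only, none or still open, it means among the compounds named here.

Compound 1 `COc1ccc(CN[C@@H]2CO[C@H](C(c3ccccc3)c3ccccc3)C[C@H]2O)cc1O` in an assay on striatum for inhibition of sodium-dependent dopamine transporter (Rattus norvegicus); on this read-out lower numbers stand for stronger inhibition and higher numbers for weaker inhibition: 58.6 nM
Compound 2 `COc1cc(O)cc(CN[C@@H]2CO[C@H](C(c3ccccc3)c3ccccc3)C[C@H]2O)c1` in this assay: 209 nM

Compound 2 has the higher of the two numbers, its nearest neighbour being compound 1. Compound 3 `O[C@@H]1C[C@@H](C(c2ccccc2)c2ccccc2)OC[C@H]1NCc1ccc2occc2c1` carries 1-benzofuran-5-yl in place of 3-hydroxy-5-methoxyphenyl on a saturated chain carbon bound to an amine nitrogen. For the measured compounds named here, the only step recorded, a 3.6-fold higher number from compound 1 to compound 2 (0.55 log units; beyond the scatter), moved oxygen groups around the same aromatic ring; it shows that changes at this position can shift the number modestly, but nothing measured speaks to swapping the ring itself. Compound 3 is therefore expected to give 150 nM, within a range of 40 nM to 600 nM, an estimated step of a 1.4-fold lower number from compound 2 to compound 3 (0.14 log units; within the scatter).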

Compound 3, inhibition constant: 234 nM
Compound 3: the middle estimate sits 1.6-fold (0.19 log units) below what was measured; the measured number falls inside the stated range.
By their numbers in this assay, from the lowest: compound 1; then compounds 2 and 3 (each within the scatter of the next).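

In this assay, 1-benzofuran-5-yl in place of 3-hydroxy-5-methoxyphenyl gives a 1.1-fold higher number from compound 2 to compound 3 (0.05 log units; within the scatter), so a group with no hydrogen-bond donor and a second aromatic ring reads the same as this single ring with its hydroxyl. Set against 3-hydroxy-4-methoxyphenyl, the same group gives a 4.0-fold higher number from compound 1 to compound 3 (0.60 log units; beyond the scatter), which leaves 3-hydroxy-4-methoxyphenyl with the lowest number of the three. Nothing at hand gives a reason for these numbers.

Still open, on these data alone, is what a ring carrying an amine or a carboxylic acid would give at this position. Also open, as far as these compounds go, is the effect of a longer chain between the ring and the nitrogen.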